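The compounds below may be only part of what the source reports. "The series", "measured", "known", "first", "only" and "open" are said of these compounds alone.

Compound 1 `CC(C)(C)n1cc2c(n1)C(=O)CC1(CCN(C(=O)c3cc(-c4ccc(Cl)cc4)nc4ccccc34)CC1)O2` gives 630 nM in a functional assay on HepG2 cells (Homo sapiens) for inhibition, read by MTT assay, with a stated time of 72 h; on this read-out higher numbers stand for weaker inhibition and lower numbers for stronger inhibition. In this assay compound 2 `COc1ccc(-c2cc(C(=O)N3CCC4(CC3)CC(=O)c3nn(C(C)(C)C)cc3O4)c3ccccc3n2)cc1` gives 2780 nM, and compound 3 `CC(C)(C)n1cc2c(n1)C(=O)CC1(CCN(C(=O)c3cc(Cl)nc4ccccc34)CC1)O2` gives 4720 nM. Compound 4 `COc1cc(C(=O)N2CCC3(CC2)CC(=O)c2nn(C(C)(C)C)cc2O3)c2ccccc2n1` has not yet been measured. Going from compound 3 to compound 4 means (methoxy in place of chloro on an aromatic carbon). The same change was made once before, as methoxy in place of chloro on an aromatic carbon, where a 4.4-fold higher number from compound 1 to compound 2 (0.64 log units; beyond the scatter). The two cores differ by chloro in place of 4-chlorophenyl on an aromatic carbon. The places are not the same: in compound 1 the change sits on a six-membered aromatic ring of carbon only, para to a large group, while in compound 3 it sits on a six-membered aromatic ring with 1 nitrogen, part of a fused or bridged system of two rings, next to the ring nitrogen, meta to a fused ring, meta to a large group and para to a fused ring, so this is the same kind of change, not the same. A smaller step is expected here, a 1.9-fold higher number from compound 3 to compound 4 (0.28 log units; within the scatter), because a 4.4-fold higher number from compound 1 to compound 2 (0.64 log units; beyond the scatter) was made at a different place. Compound 4 is expected to give about 9000 nM in this assay, likely between 3500 nM and 25000 nM.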

Compound 4, half-maximal inhibitory concentration: > 10000 nM
Compound 4: only a limit was reported (the forecaster's own chance of this, stated with the estimate: 15%); at least 1.1-fold (0.04 log units) between middle value and limit.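

In this assay compound 4 gives > 10000 nM as a limit of the assay and not as a number. Methoxy in place of 4-methoxyphenyl gives an at least 3.5-fold higher number from compound 2 to compound 4 (0.55 log units; beyond the scatter) and methoxy in place of 4-chlorophenyl gives an at least 15-fold higher number from compound 1 to compound 4 (1.20 log units; beyond the scatter) in this series. Methoxy in place of chloro gives an at least 2.1-fold higher number from compound 3 to compound 4 (0.32 log units; beyond the scatter) and so weakens inhibition on both cores, but these two cores show only a shared direction, not whether the size of the step carries over: the same change on two cores in this assay, a 4.4-fold higher number (0.64 log units; beyond the scatter) from compound 1 to compound 2 and an at least 2.1-fold higher number (0.32 log units; beyond the scatter) from compound 3 to compound 4; the limit leaves it open whether they differ.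

The compounds shown leave open how an amine or a longer chain such as ethoxy would read on that same aromatic carbon. They also leave open whether the direction would hold on any further core.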